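The source may report more compounds than this note shows. Statements on the series, on what has been measured and on what is new or still open speak of the compounds shown alone.

Compound 1 `N/C(=N\NC(=S)N1CCCC1)c1ccc(F)cn1`: 52.6%; compound 2 `N/C(=N\NC(=S)N1CCSCC1)c1ccc(F)cn1`: 35.4%.

Both numbers come from a functional assay on MCF7 cells (Homo sapiens) for cytotoxicity, read by MTT assay, with a stated time of 72 h, tested at 3 uM; on this read-out lower numbers stand for less inhibition of growth and higher numbers for more inhibition of growth at the one concentration tested. For the measured compounds named here, compound 2 gives the lower of the two, with compound 1 as its only neighbour; replacing pyrrolidin-1-yl by thiomorpholin-4-yl on the thiocarbonyl carbon gave a number 17.2 percentage points lower from compound 1 to compound 2 (beyond the scatter). Compound 3 `N/C(=N\NC(=S)N1CCOCC1)c1ccc(F)cn1` differs from compound 2 in one place: morpholin-4-yl in place of thiomorpholin-4-yl on a thiocarbonyl carbon. Going by the values given here, no measured step swaps these two groups, so only the step just named bears on it, and it shows a modest change at this place. For compound 3 the expected step is a number 1.6 percentage points higher from compound 2 to compound 3 (within the scatter), with no clear direction. The estimate for compound 3 is 37%, between 20% and 55%.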

Compound 3, percent growth inhibition at one concentration: 33.9%
Compound 3: middle estimate off by 3.1 percentage points, on the high side, and the stated range covers the measured number.
By their numbers in this assay, from the lowest: compounds 3 and 2 (each within the scatter of the next); then compound 1.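

Morpholin-4-yl and thiomorpholin-4-yl on the thiocarbonyl carbon cannot be told apart in this assay (a number 1.5 percentage points lower from compound 2 to compound 3 (within the scatter)), so exchanging the ring sulfur for oxygen shows no clear effect here. Morpholin-4-yl also gives a lower number than pyrrolidin-1-yl (a number 18.7 percentage points lower from compound 1 to compound 3 (beyond the scatter)), so among these three compounds, the clear difference separates pyrrolidin-1-yl from both six-membered rings. Nothing available explains these numbers.

On these data alone, whether ring size or the second hetero atom matters remains open. Piperidin-1-yl, with its six-membered ring and only the ring nitrogen, would help separate the two, while dimethylamino would extend the comparison to an open-chain amine.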